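Three Methoxy Groups in Place of One on Compound 2

A few compounds are considered here, and "the series" means these few. Any claim that something is new, unique, unknown or untested is made for them only; others in the source may bear on it.

Among the measured compounds shown here, compound 2 `COc1ccc(C2=NN(C(=O)c3cccnc3)C(c3cn(C)c4ccc(Br)cc34)C2)cc1` gives 1190 nM in a functional assay on A549 cells (Homo sapiens) for inhibition, read by MTT assay, with a stated time of 48 h (on this read-out lower numbers stand for stronger inhibition of growth and higher numbers for weaker inhibition of growth), the lowest of the two numbers measured so far. Compound 1 `Cn1cc(C2CC(c3ccc(Cl)cc3)=NN2C(=O)c2cccnc2)c2cc(Br)ccc21` gives 7650 nM. For the measured compounds named here, the single measured step, a 6.4-fold lower number from compound 1 to compound 2 (0.81 log units; beyond the scatter), came with a methoxy in place of chloro on an aromatic carbon. Compound 3 `COc1cc(C2=NN(C(=O)c3cccnc3)C(c3cn(C)c4ccc(Br)cc34)C2)cc(OC)c1OC` differs from compound 2 by 3,4,5-trimethoxyphenyl in place of 4-methoxyphenyl on a carbon with a double bond to nitrogen. Going by the values given here, no measured step bears directly on this change: the step from compound 1 to compound 2 exchanged one group for another, whereas here 3,4,5-trimethoxyphenyl replaces 4-methoxyphenyl, a larger group with more hydrogen-bond acceptors. Without a guide, compound 3 is expected to move only modestly, giving a 1.7-fold lower number from compound 2 to compound 3 (0.23 log units; within the scatter) in this assay, a shift that may stay within the scatter. Compound 3 is therefore estimated at 700 nM, with a range from 200 nM to 3000 nM.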

Compound 3, concentration for 50% growth inhibition: > 10000 nM
Compound 3 was reported as a limit; the forecaster's own chance of this, stated with the estimate: 5%; at least 14-fold (1.15 log units) between middle value and limit.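

Moving from one methoxy group to three at this position reverses the gain that the single methoxy gave over chloro: 3,4,5-trimethoxyphenyl in place of 4-methoxyphenyl, on the carbon with a double bond to nitrogen, gives an at least 8.4-fold higher number from compound 2 to compound 3 (0.92 log units; beyond the scatter). Against the chloro compound, 3,4,5-trimethoxyphenyl in place of 4-chlorophenyl gives an at least 1.3-fold higher number from compound 1 to compound 3 (0.11 log units; that floor lies within the scatter), a floor that does not by itself separate the two compounds. The result for compound 3 is a limit and not a number: the limit of > 10000 nM in this assay, at which 1 of the 3 values shown sits.

As far as these compounds go, how far compound 3 lies beyond that limit remains open, and so does which of its added methoxy groups goes with the weaker inhibition. A dimethoxyphenyl group would test that second point, and a hydroxyphenyl or aminophenyl group would show how other substituents fare here.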